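Series notes: aminophenyl to aminopropyl on the core

The source may hold more compounds than are shown below. What is called first, only, known or untested is meant among the compounds shown, and "the series" means these compounds.

Two compounds carry measurements so far. Compound 1 `Nc1ccc(Nc2c(C(=O)NCc3ccc(F)cc3)nc(Br)c3cccnc23)cc1` gives 4000 nM in a functional assay on MCF7 cells (Homo sapiens) for cytotoxicity, read by MTT assay, with a stated time of 72 h (a higher number here means a weaker inhibitor, a lower number a stronger inhibitor), the lower of the two numbers shown. Compound 2 `CS(=O)(=O)NCCCCCCN(c1nc(C(=O)NCc2ccc(F)cc2)c(O)c2ncccc12)S(C)(=O)=O` gives 7000 nM in this assay, and the gap between compound 2 and compound 1 lies within the scatter, so no order can be read between them.

Compound 3 `NCCCNc1c(C(=O)NCc2ccc(F)cc2)nc(Br)c2cccnc12` is not yet measured. It differs from compound 1 in one place: 3-aminopropyl in place of 4-aminophenyl on a nitrogen on an aromatic ring. The substituent on the nitrogen on an aromatic ring thus loses its ring and becomes a short chain ending in an amine. Among the compounds with values here, no measured pair in this set shows such a change, so no size of step is known for it. Pending the number, the step from compound 1 to compound 3 is expected to be small, and the estimate a 1.5-fold higher number from compound 1 to compound 3 (0.18 log units; within the scatter) sits close to the scatter rather than beyond it. Compound 3 is therefore expected to give about 6000 nM in this assay, within a range from 2000 nM to 20000 nM.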

Compound 3, half-maximal inhibitory concentration: 6000 nM
Compound 3: middle estimate and measured number agree at the digits printed; the measured number falls inside the stated range.
By their numbers in this assay, from the lowest: compounds 1, 3 and 2 (each within the scatter of the next).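

At the nitrogen on an aromatic ring, 3-aminopropyl in place of 4-aminophenyl gives a 1.5-fold higher number from compound 1 to compound 3 (0.18 log units; within the scatter) in this assay, so at this place the six-membered aromatic ring of carbon only can give way to a chain with no ring and the two numbers cannot be told apart. Within the data shown here, this is the first pair that differs in one place; both groups end in an amine, so it speaks to the ring and not to the amine. No measured data bear on why the two groups read alike.

Open, as far as these compounds go, is whether a hydroxyl or a carboxylic acid in place of the amine at the chain end would keep the number within the scatter of compound 3. Also open, from the compounds shown here alone, is whether a longer chain ending in an amine on the same nitrogen would do so.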